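Crotonamide series: hydroxy for bromo on the benzyl ring

The source may hold more compounds than are shown below. What is called first, only, known or untested is meant among the compounds shown, and "the series" means these compounds.

Measured so far:
- compound 1, `C/C=C/C(=O)N(Cc1cc(OC)c(OC)c(OC)c1)c1ccc(OC)c(O)c1`: 8450 nM
- compound 2, `C/C=C/C(=O)N(Cc1ccc(OC)c(Br)c1)c1cc(OC)c(OC)c(OC)c1`: 2800 nM
- compound 3, `COc1ccc(CNc2cc(OC)c(OC)c(OC)c2)cc1Cl`: 41700 nM

In a functional assay on HCT-116 cells (Homo sapiens) for inhibition, read by MTT assay, with a stated time of 48 h (a higher number here means a weaker inhibitor, a lower number a stronger inhibitor), compound 2 gives 2800 nM, the lowest of the three numbers. Compound 1 is the nearest, its number higher than that of compound 2 by a margin beyond the scatter; compound 3, which lacks the crotonamide carbonyl and carries a secondary amine instead, is the furthest, again beyond the scatter. For the measured compounds named here, with only three compounds and no pair differing in one place, no step size can be read off directly.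

Compound 4, `C/C=C/C(=O)N(Cc1ccc(OC)c(O)c1)c1cc(OC)c(OC)c(OC)c1`, is not yet measured. Its difference from compound 2 is the following: hydroxy in place of bromo on an aromatic carbon. The hydroxy-bearing ring of compound 4 also appears in compound 1, though there it sits on the other nitrogen substituent, so compound 1 is only an indirect pointer.

Expectation: a hydroxy for bromo exchange at this position is estimated to cost some potency, but not much; the step is expected to be about a 1.6-fold higher number from compound 2 to compound 4 (0.21 log units; within the scatter), which could still fall within the scatter. Compound 4 is therefore estimated at 4500 nM, with a likely range from 1500 nM to 13000 nM.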

Compound 4, half-maximal inhibitory concentration: 55 nM
Estimate against measurement, compound 4: 82-fold (1.91 log units) above; measured number outside the range, below it.
By their numbers in this assay, from the lowest: compound 4; then compound 2; then compound 1; then compound 3.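

In this assay, hydroxy in place of bromo on the 3-bromo-4-methoxyphenyl ring gives a 51-fold lower number from compound 2 to compound 4 (1.71 log units; beyond the scatter) and makes this aromatic carbon, ortho to a methoxy group, highly sensitive to a change of one heavy atom. The earlier compounds shown here could not show this, since no two of them differed in one place. Hydroxy adds a hydrogen-bond donor and a hydrogen-bond acceptor where bromo has neither, but no measurement shown ties the step to either feature or to any other property of the group.

From the compounds shown here alone, it remains open whether the gain is specific to hydroxy or comes largely from the loss of bromo, and an amine or a fluoro on the same aromatic carbon would help separate those two readings. Going by these compounds, it is also open whether a step of this size holds elsewhere, since it rests on a single pair in this assay and a matching exchange on another crotonamide would be needed to test it.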